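The compounds below may be only part of what the source reports. "The series", "measured", "known", "first", "only" and "open" are said of these compounds alone.

Of the compounds shown here, two with the same core have been measured so far. In a functional assay on MCF7 cells (Homo sapiens) for inhibition, read by sulforhodamine B assay, with a stated time of 48 h, tested at 50 uM (on this read-out higher numbers stand for more inhibition of growth at the one concentration tested and lower numbers for less inhibition of growth), compound 1 (`CCCOc1ccc([C@@H]2CC(=O)c3cc(CC=C(C)C)c(OC)cc3O2)cc1`) gives 60% and compound 2 (`C#CCOc1ccc([C@@H]2CC(=O)c3cc(CC=C(C)C)c(OC)cc3O2)cc1`) gives 68%. These two values lie within the scatter of each other, so the data do not separate compound 2 from compound 1.

The next compound, compound 3 (`COc1cc2c(cc1CC=C(C)C)C(=O)C[C@@H](c1ccc(Oc3ccccc3)cc1)O2`), keeps the core and exchanges one group: phenyl in place of propargyl on an oxygen on an aromatic ring. This is phenyl in place of propargyl on an oxygen on an aromatic ring, so propargyloxy becomes phenoxy. Within the data shown here, only one measured step bears on this exchange, since it also alters the group on that oxygen, and it amounts to a number 8 percentage points higher from compound 1 to compound 2 (within the scatter). Among the measured compounds shown here, that step stays within the scatter, but no measured compound carries a ring on that oxygen, so it is only a weak guide and the range must stay wide. The estimate is a number 6 percentage points lower from compound 2 to compound 3 (within the scatter), which means that no step beyond the scatter is expected in either direction in this assay. For compound 3 the estimated value is 62%, with an expected range from 42% to 80%.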

Compound 3, percent growth inhibition at one concentration: 69%
Estimate against measurement, compound 3: 7 percentage points below; low and high end bracket the measured number.
By their numbers in this assay, from the lowest: compounds 1, 2 and 3 (each within the scatter of the next).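

Placing a ring on this oxygen is the new element here, and in this assay the change from propargyl to phenyl gives a number 1 percentage points higher from compound 2 to compound 3 (within the scatter), while the change from propyl to phenyl gives a number 9 percentage points higher from compound 1 to compound 3 (within the scatter) on the same read-out. Phenyl brings 6 heavy atoms against the 3 of propargyl, along with a six-membered aromatic ring, yet this larger group produces no difference that can be separated from the scatter, so propyl, propargyl and phenyl on this oxygen cannot be put in any order. The data offer no explanation for this outcome.

Propargyl and phenyl contain only carbon, so it remains open how a group carrying other atoms on this oxygen, such as an amine, a carboxylic acid or a phenyl ring bearing a fluorine, would behave. All these numbers also come from a single concentration, which leaves open whether compounds that look alike here would still look alike at lower concentrations.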